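A few compounds are considered here, and "the series" means these few. Any claim that something is new, unique, unknown or untested is made for them only; others in the source may bear on it.

Measured so far:
- compound 1, `C=CCn1c(=S)n(C2OC(COCc3ccccc3)[C@H]3OC(C)(C)O[C@@H]23)c2nc(N)nc(O)c21`, 47 uM
- compound 2, `[N-]=[N+]=NCC(O)Cn1c(=O)n(C2OC(CO)[C@@H](O)[C@H]2O)c2nc(N)nc(O)c21`, 39 uM
- compound 3, `CCCn1c(=O)n(C2CCC(COC(C)=O)O2)c2nc(NC(C)=O)nc(O)c21`, 154 uM

All three compounds share a core and were tested in a functional assay (B cells) with Mus musculus as the target; a lower number here means that less compound is needed, a higher number that more compound is needed for the effect. Compound 2 gives the lowest of the three numbers. Compound 1 sits nearest to it, and the gap between compound 2 and compound 1 lies within the usual scatter, so no order between them is claimed. Compound 3 is furthest, with a gap to compound 2 that lies beyond the scatter. Among the compounds with values here, no step between two measured compounds differing in a single place is available, so nothing is known about how any one change moves the number.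

Compound 4, `CCn1c(=O)n(C2OC(CO)[C@@H](O)[C@H]2O)c2nc(N)nc(O)c21`, has not yet been measured in this assay. It differs from compound 2 in one place: methyl in place of 2-azido-1-hydroxyethyl on a saturated chain carbon bound to an aromatic nitrogen.

Within the data shown here, with no single-change step to lean on, only the spread of the three values gives a sense of scale. The chain on the aromatic nitrogen varies across compounds 1, 2 and 3 without a clear tie to the numbers. The step of a 1.4-fold higher number from compound 2 to compound 4 (0.15 log units; within the scatter) is therefore expected to be small, close to the scatter, and its direction is uncertain. Compound 4 is estimated at 55 uM in this assay, with a range from 20 uM to 150 uM.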

Compound 4, concentration for half-maximal effect: 15 uM
The estimate for compound 4 lay 3.7-fold (0.56 log units) above the measured number; the whole stated range lies above it.
By their numbers in this assay, from the lowest: compound 4; then compounds 2 and 1 (each within the scatter of the next); then compound 3.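

Within the data shown here, the first single-change step falls on the chain at the aromatic nitrogen: in this assay, methyl in place of 2-azido-1-hydroxyethyl on a saturated chain carbon bound to an aromatic nitrogen gives a 2.6-fold lower number from compound 2 to compound 4 (0.41 log units; beyond the scatter), a modest step beyond the scatter. This position therefore responds to what it carries, which the three earlier compounds could not show, and on this core the short ethyl chain gives the lower number without the azide or the hydroxyl of the 3-azido-2-hydroxypropyl chain. No measurement at hand bears on why the number falls, so the step stands as an observation only.

The azide and the hydroxyl leave in the same step, so their separate contributions remain unresolved, and a single pair cannot show whether the number follows chain length, the groups on the chain, or both. On the core of compound 4, a 2-hydroxypropyl chain, a 3-azidopropyl chain, a butyl chain or a 3-aminopropyl chain would each test one of these questions at this position.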